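A few compounds are considered here, and "the series" means these few. Any claim that something is new, unique, unknown or untested is made for them only; others in the source may bear on it.

Compound 1 `C[C@H](NC(=O)c1c(C(F)(F)F)nnn1CCOc1ccc(F)cc1)c1ccc(C(=O)O)cc1` gives 276 nM in a functional assay on CHO cells for antagonist activity at prostaglandin E2 receptor EP4 subtype (Homo sapiens), read by calcium flux, with a stated time of 15 min; on this read-out higher numbers stand for weaker inhibition and lower numbers for stronger inhibition. Compound 2 `C[C@H](NC(=O)c1cnnn1Cc1ccc(C(F)(F)F)cc1)c1ccc(C(=O)O)cc1` gives only a limit in this assay, > 10000 nM. Compound 3 `C[C@H](NC(=O)c1c(C2CC2)nnn1Cc1ccc(C(F)(F)F)cc1)c1ccc(C(=O)O)cc1` gives 52.1 nM in this assay.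

Within the data shown here, of the two numbers known, compound 3 gives the lower one, and compound 1 gives the higher one. Compound 4 `C[C@H](NC(=O)c1c(C2=CCOCC2)nnn1Cc1ccc(C(F)(F)F)cc1)c1ccc(C(=O)O)cc1` carries a group of 6 heavy atoms (5 carbon, 1 oxygen; one six-membered non-aromatic ring with 1 hetero atom) in place of a group of 3 heavy atoms (3 carbon; one three-membered non-aromatic ring of carbon only), on an aromatic carbon. Among the measured compounds shown here, the one measured step that bears on this position is an at least 190-fold lower number from compound 2 to compound 3 (2.28 log units; beyond the scatter), which shows that a ring group at this aromatic carbon matters greatly. Because of that large step an at least 190-fold lower number from compound 2 to compound 3 (2.28 log units; beyond the scatter) a ring group is kept here, so no further change beyond the scatter is expected. Compound 4 is estimated at 60 nM in this assay, between 20 nM and 200 nM, a step of a 1.2-fold higher number from compound 3 to compound 4 (0.06 log units; within the scatter).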

Compound 4, half-maximal inhibitory concentration: 119 nM
Compound 4: the middle estimate sits 2.0-fold (0.30 log units) below what was measured; the measured number falls inside the stated range.
By their numbers in this assay, from the lowest: compound 3; then compound 4; then compound 1. At a limit, above all of these: compound 2.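

This aromatic carbon accepts more than a small carbon ring: the six-membered ring with one hetero atom in compound 4 also gives a large gain over hydrogen, with an at least 84-fold lower number from compound 2 to compound 4 (1.92 log units; beyond the scatter). Compound 2 gives a limit, not a number: the limit of > 10000 nM in this assay, at which 1 of the 4 values shown sits. The larger ring is still not equal to cyclopropyl, with a 2.3-fold higher number from compound 3 to compound 4 (0.36 log units; beyond the scatter).

On these data alone, it remains open how an amine or a longer carbon chain on this carbon would compare. Also open, as far as these compounds go, is whether the ring oxygen or the double bond of compound 4 affects its number.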